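Methoxy for chloro on the sulfonyl ring, cytotoxicity

The compounds below may be only part of what the source reports. "The series", "measured", "known", "first", "only" and "open" are said of these compounds alone.

Compound 1 `O=S(=O)(Nc1ccc2oc(-c3ccccc3)nc2c1)c1ccccc1Cl` gives 73000 nM in an ADME assay on HEK293 cells (Homo sapiens) for cytotoxicity, read by resazurin assay, with a stated time of 48 h (a lower number here means that less compound is tolerated, a higher number that more compound is tolerated), the lowest of the two numbers shown. Compound 3 `Cc1ccc(S(=O)(=O)Nc2ccc(-c3nc4ccccc4o3)cc2)cc1` gives 88000 nM in this assay, within the scatter of compound 1. Compound 2 `O=S(=O)(Nc1ccc(-c2nc3ccccc3o2)cc1)c1ccc(Cl)s1` gives only a limit of the assay, > 100000 nM in this assay (the limit of > 100000 nM in this assay, at which 1 of the 3 values shown sits). Within the data shown here, the one measured step, an at least 1.1-fold lower number from compound 2 to compound 3 (0.05 log units; that floor lies within the scatter), alters the group on the sulfonyl sulfur and stays within the scatter. Compound 4 `COc1ccccc1S(=O)(=O)Nc1ccc2oc(-c3ccccc3)nc2c1` differs from compound 1 by methoxy in place of chloro on an aromatic carbon, again on the ring bound to the sulfonyl sulfur. Among the measured compounds shown here, with the only comparable step within the scatter, no step beyond the scatter is expected in this assay. The expected shift for compound 4 is a 1.1-fold higher number from compound 1 to compound 4 (0.04 log units; within the scatter). Compound 4 is estimated at 80000 nM, between 40000 nM and 160000 nM.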

Compound 4, half-maximal cytotoxic concentration: 41000 nM
For compound 4 the middle estimate is 2.0-fold (0.29 log units) above the measured one; measured number inside the range.
By their numbers in this assay, from the lowest: compounds 4, 1 and 3 (each within the scatter of the next, the first and the last beyond it). At a limit, above all of these: compound 2.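

In this assay the change from 2-chlorophenyl to 2-methoxyphenyl gives a 1.8-fold lower number from compound 1 to compound 4 (0.25 log units; within the scatter), so this place, ortho to a large group, takes either group without a step beyond the scatter. The earlier step altered the whole group on the sulfonyl sulfur, whereas this one shows that a hydrogen-bond acceptor entering on this aromatic carbon does not carry the number beyond the scatter. Nothing measured here gives a cause for this step. From the compounds shown here alone, whether an amine or a carboxylic acid on this carbon would leave the scatter remains open.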